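Cyclopentyl in place of 2-methoxyethyl on an aromatic oxygen

The source may report more compounds than this note shows. Statements on the series, on what has been measured and on what is new or still open speak of the compounds shown alone.

Measured so far in a functional assay on SH-SY5Y cells (Homo sapiens) for antagonist activity, read by cAMP accumulation; a higher number here means a more potent compound, by a factor of ten per unit of this negative logarithm, a lower number a less potent compound
Compound 1 `CCOc1ccc(Cc2ccc(NC3=NCCN3)cc2)cc1` gives 8.2
Compound 2 `CCCCOc1ccc(Cc2ccc(NC3=NCCN3)cc2)cc1` gives 9
Compound 3 `COCCOc1ccc(Cc2ccc(NC3=NCCN3)cc2)cc1` gives 8

Compound 3 stands at 8 in this series, with a number 0.20 log units lower from compound 1 to compound 3 (within the scatter) and, further off, a number 1.00 log units lower from compound 2 to compound 3 (beyond the scatter). Compound 4 `c1cc(NC2=NCCN2)ccc1Cc1ccc(OC2CCCC2)cc1` has not yet been measured. It carries cyclopentyl in place of 2-methoxyethyl on an oxygen on an aromatic ring, (cyclopentyl in place of 2-methoxyethyl on an oxygen on an aromatic ring). Among the compounds with values here, no measured step makes this exact change. The nearest guides are the step above to compound 3 from compound 2 and a number 0.80 log units higher from compound 1 to compound 2 (beyond the scatter), since the entering group, like the chain of compound 2, holds carbon only. A modest rise is therefore expected in this assay, an estimated a number 0.70 log units higher from compound 3 to compound 4 (beyond the scatter). Compound 4 is estimated at 8.7, with an expected range from 8.1 to 9.3.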

Compound 4, negative logarithm of the antagonist equilibrium constant: 8.9
Estimate against measurement, compound 4: 0.20 log units below, within the range that was stated.
By their numbers in this assay, from the lowest: compounds 3 and 1 (each within the scatter of the next); then compounds 4 and 2 (each within the scatter of the next).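

The step of a number 0.10 log units lower from compound 2 to compound 4 (within the scatter) on replacing butyl with cyclopentyl shows that in this assay this aromatic oxygen accepts a five-membered carbon ring as readily as an open butyl chain. The steps of a number 0.90 log units higher from compound 3 to compound 4 (beyond the scatter) and a number 0.70 log units higher from compound 1 to compound 4 (beyond the scatter) show that the ring also keeps the number clearly above those of the 2-methoxyethyl and ethyl compounds.

As far as these compounds go, whether cyclohexyl, phenyl or a longer chain such as hexyl would hold that level on this oxygen remains open. No measurement given here accounts for these steps.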